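The source may hold more compounds than are shown below. What is called first, only, known or untested is meant among the compounds shown, and "the series" means these compounds.

Compound 1 `O=c1ccoc2ccc(OCCc3ccccc3)cc12`: 21 nM
Compound 2 `O=c1ccoc2ccc(OCCCc3ccccc3)cc12`: 57 nM

In an assay on microsomes for inhibition of Amine oxidase [flavin-containing] B (Homo sapiens), read by fluorescence and spectrophotometry, with a stated time of 20 min (a lower number here means a stronger inhibitor, a higher number a weaker inhibitor), compound 2 gives the higher of the two numbers, standing a 2.7-fold higher number from compound 1 to compound 2 (0.43 log units; beyond the scatter). Compound 3 `O=c1ccoc2ccc(OCCc3ccc(Br)cc3)cc12` differs from compound 2 by 4-bromophenyl in place of benzyl on a saturated chain carbon, two bonds along the chain from an oxygen on an aromatic ring. Going by the values given here, the only measured step that bears on this is the one from compound 1 to compound 2, where lengthening the chain gave a 2.7-fold higher number from compound 1 to compound 2 (0.43 log units; beyond the scatter); compound 3 reverses that lengthening, so a step back toward the level of compound 1 is expected. Among the compounds with values here, no measured step shows what the bromine adds, so the estimate stays loose. For compound 3 the expected result is 15 nM, within 4 nM to 60 nM, an expected step of a 3.8-fold lower number from compound 2 to compound 3 (0.58 log units; beyond the scatter).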

Compound 3, half-maximal inhibitory concentration: 27 nM
For compound 3 the middle estimate is 1.8-fold (0.26 log units) below the measured one; the range from low to high includes it.
By their numbers in this assay, from the lowest: compounds 1 and 3 (each within the scatter of the next); then compound 2.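

Bromo in place of hydrogen on an aromatic carbon gives a 1.3-fold higher number from compound 1 to compound 3 (0.11 log units; within the scatter), so the 4-bromophenyl group is tolerated on the shorter chain. The change of benzyl to 4-bromophenyl gives a 2.1-fold lower number from compound 2 to compound 3 (0.32 log units; beyond the scatter), and since the bromine itself shifts the number so little, this step tracks the shorter chain rather than the halogen. Nothing here explains why the bromine leaves the number in place.

Going by these compounds, whether a chloro, methoxy or amine group at that spot on the phenyl ring would be tolerated equally remains open. So does whether bromo would behave the same way on the longer chain.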